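Moving the Fluorine Around the Phenyl Ring

The source may report more compounds than this note shows. Statements on the series, on what has been measured and on what is new or still open speak of the compounds shown alone.

Going by the values given here, compound 2, `COc1cc(C(F)(F)F)cc(SC)c1C(=O)NC1(c2ccc(F)cc2)CCCN(C)C1`, is one of two compounds measured in an assay on cells for inhibition of sodium- and chloride-dependent glycine transporter 1 (Homo sapiens); a higher number here means that more compound is needed for the effect, a lower number that less compound is needed; compound 2 gives 26 nM. Compound 1, `CN1CCCC(NC(=O)c2ccc(C(F)(F)F)cc2F)(c2ccccc2)C1`, gives 9900 nM in this assay, so compound 2 stands with the lower of the two numbers, and the gap between them lies beyond the usual scatter. Compound 3, `COc1cc(C(F)(F)F)cc(SC)c1C(=O)NC1(c2cccc(F)c2)CCCN(C)C1`, keeps everything in compound 2 except one change: 3-fluorophenyl in place of 4-fluorophenyl on a saturated ring carbon. The fluorine thus moves within the same phenyl ring, with all atoms kept and only their arrangement altered. Among the compounds with values here, no measured pair in this set shows what such a rearrangement does, so the expectation rests on compound 2 alone. A shift of this kind is expected to cost little, perhaps a small step upward, and the step from compound 2 to compound 3 is estimated as a 1.7-fold higher number from compound 2 to compound 3 (0.24 log units; within the scatter). For compound 3 the expected value in this assay is 45 nM, within a range from 12 nM to 200 nM.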

Compound 3, half-maximal effective concentration: 48 nM
Beside the measured number, compound 3's estimate is 1.1-fold (0.03 log units) below it, within the range that was stated.
By their numbers in this assay, from the lowest: compounds 2 and 3 (each within the scatter of the next); then compound 1.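

In this assay, the change from 4-fluorophenyl to 3-fluorophenyl on this saturated ring carbon gives a 1.8-fold higher number from compound 2 to compound 3 (0.27 log units; within the scatter) and so has no clear effect on the number. Compound 1 and compound 2 differ in more than one place and could not show this, whereas this pair isolates the fluorine's place on the phenyl ring and shows that, on the core of compound 2, either of these two arrangements gives a similar result. Nothing available here explains why the two arrangements read alike.

The compounds shown leave open whether this phenyl ring needs its fluorine at all on this core, and whether a chlorophenyl or a pyridine ring would serve equally well on the same carbon. Going by these compounds alone, they also leave open whether this tolerance would hold with a different amide part, such as the one in compound 1.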